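The source may hold more compounds than are shown below. What is called first, only, known or untested is meant among the compounds shown, and "the series" means these compounds.

Among the compounds with values here, in a functional assay on COLO 205 cells (Homo sapiens) for cytotoxicity, read by sulforhodamine B assay, with a stated time of 48 h (a higher number here means a weaker inhibitor, a lower number a stronger inhibitor), compound 1 (`COc1cc(/C=C/C(=O)/C=C/c2cccc3ccccc23)ccc1OCc1cn(CCOc2cc(=O)oc3ccccc23)nn1`) gives 9950 nM as its result, and compound 2 (`COc1cc(/C=C/C(=O)/C=C/c2cc(OC)c(OC)c(OC)c2)ccc1OCc1cn(CCOc2cc(=O)oc3ccccc23)nn1`) gives 4680 nM as the lowest of the two numbers measured so far. Within the data shown here, the only measured step is a 2.1-fold lower number from compound 1 to compound 2 (0.33 log units; beyond the scatter) and it places 3,4,5-trimethoxyphenyl where naphthalen-1-yl stood. Compound 3 (`COc1ccc(/C=C/C(=O)/C=C/c2ccc(OCc3cn(CCOc4cc(=O)oc5ccccc45)nn3)c(OC)c2)cc1OC`) differs from compound 2 by one small edit (hydrogen in place of methoxy on an aromatic carbon) with hydrogen in place of methoxy on an aromatic carbon, so 3,4,5-trimethoxyphenyl becomes 3,4-dimethoxyphenyl. Among the measured compounds shown here, no measured step removes a single methoxy, so the evidence is thin. Even the exchange of that whole group gave only a modest step (a 2.1-fold lower number from compound 1 to compound 2 (0.33 log units; beyond the scatter)) in this assay and so a smaller shift is expected here, with a slightly higher number as the better guess. The estimated step is a 1.3-fold higher number from compound 2 to compound 3 (0.11 log units; within the scatter) and it may not clear the usual scatter. Compound 3 is therefore estimated at 6000 nM with a range of 3000 nM to 12000 nM expected for it.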

Compound 3, half-maximal inhibitory concentration: 6780 nM
Beside the measured number, compound 3's estimate is 1.1-fold (0.05 log units) below it; low and high end bracket the measured number.
By their numbers in this assay, from the lowest: compounds 2, 3 and 1 (each within the scatter of the next, the first and the last beyond it).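

In this assay, hydrogen in place of methoxy on this aromatic carbon, ortho to a methoxy group, gives a 1.4-fold higher number from compound 2 to compound 3 (0.16 log units; within the scatter) and so leaves the result inside the normal noise of the measurement. This single methoxy therefore shows no measurable effect on the number in this assay. Naphthalen-1-yl and 3,4-dimethoxyphenyl also cannot be told apart, with a 1.5-fold lower number from compound 1 to compound 3 (0.17 log units; within the scatter) as their step, and nothing available gives a reason for either result.

The compounds shown leave open whether a different group on this same carbon, such as an amine, a carboxylic acid or a longer alkoxy chain, would shift the number beyond the scatter. They also leave open whether a hydroxy group in place of either remaining methoxy would do so.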